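This account rests on a few compounds, and the source may have more. Where it says the series, first, only, none or still open, it means among the compounds named here.

Measured compounds:
Compound 1, `O=C1N=C(N2N=C(c3ccccc3)CC2c2ccccc2O)S/C1=C1/C(=O)Nc2ccccc21`: 2410 nM
Compound 2, `O=C1N=C(N2N=C(c3ccccc3)CC2c2ccccc2O)S/C1=C1/C(=O)Nc2ccc(Br)cc21`: 280 nM
Compound 3, `COc1ccc(C2=NN(C3=NC(=O)/C(=C4\C(=O)Nc5ccccc54)S3)C(c3ccc(OC)cc3)C2)cc1`: 92200 nM

All three were tested in a functional assay on cells (Cancer cell lines, Homo sapiens) for cytotoxicity, read by sulforhodamine B assay, with a stated time of 48 h; on this read-out lower numbers stand for stronger inhibition of growth and higher numbers for weaker inhibition of growth. Compound 1 gives 2410 nM in this assay, and compound 2 gives 280 nM. The two differ in one place, (bromo in place of hydrogen on an aromatic carbon), and this change made a step of an 8.6-fold lower number from compound 1 to compound 2 (0.93 log units; beyond the scatter). Compound 3 shares the bromine-free pattern of compound 1 on the fused ring but carries a different core; how the two cores differ is not broken down here. In this assay compound 3 gives 92200 nM, the highest number of the three.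

Compound 4, `COc1ccc(C2=NN(C3=NC(=O)/C(=C4\C(=O)Nc5ccc(Br)cc54)S3)C(c3ccc(OC)cc3)C2)cc1`, has not yet been measured. It differs from compound 3 by bromo in place of hydrogen on an aromatic carbon, the same change, at the same place, as that from compound 1 to compound 2. Because that earlier change gave an 8.6-fold lower number from compound 1 to compound 2 (0.93 log units; beyond the scatter), a step of similar direction is expected for compound 4, though the different core of compound 3 leaves its size uncertain; the expected step is a 7.7-fold lower number from compound 3 to compound 4 (0.89 log units; beyond the scatter). Compound 4 is therefore estimated at 12000 nM in this assay, expected to lie between 3000 nM and 50000 nM.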

Compound 4, concentration for 50% growth inhibition: 240 nM
Compound 4: middle estimate off by 50-fold (1.70 log units), on the high side; the measured number lies below the stated range.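

In this assay, bromo in place of hydrogen on an aromatic carbon lowered the number on both cores, and on the core of compound 3 the result was a 380-fold lower number from compound 3 to compound 4 (2.58 log units; beyond the scatter), so the direction of the change carried over. Its size did not carry over, and the two steps differ clearly: the same change on two cores in this assay, an 8.6-fold lower number (0.93 log units; beyond the scatter) from compound 1 to compound 2 and a 380-fold lower number (2.58 log units; beyond the scatter) from compound 3 to compound 4, 45-fold (1.65 log units) apart, beyond the scatter of two such steps. Going by these compounds alone, with only two pairs, this gives no size to expect on a further core, and it does not show which of the differences between the two cores accounts for the gap.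

The compounds shown leave open whether chloro, fluoro or an amine at the same place would give steps that differ between the two cores in the same way. They also leave open whether bromo on another carbon of that six-membered aromatic ring would give a similar result on either core.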